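Swapping the benzyl group for a thiourea on the ring nitrogen

The source may hold more compounds than are shown below. What is called first, only, known or untested is meant among the compounds shown, and "the series" means these compounds.

Measured compounds:
- Compound 1 `N#Cc1ccccc1CN1CCc2c(sc(NC(=O)c3ccccc3Cl)c2C(N)=O)C1`: > 50000 nM
- Compound 2 `NC(=O)c1c(NC(=O)c2ccccc2Cl)sc2c1CCN(Cc1c(Cl)cccc1Cl)C2`: 28800 nM
- Compound 3 `NC(=O)c1c(NC(=O)c2ccccc2F)sc2c1CCN(Cc1c(Cl)cccc1Cl)C2`: 33000 nM

Of the compounds shown here, three sharing one core have been tested in a functional assay on HeLa cells (Homo sapiens) for antiproliferative activity, with a stated time of 24 h; a lower number here means a stronger inhibitor, a higher number a weaker inhibitor. Compound 1 reaches only the limit of the assay, (the limit of > 50000 nM in this assay, at which 1 of the 3 values shown sits), so it has no number. Compound 2 gives the lowest of the two numbers, and compound 3 sits close to it: a 1.1-fold higher number from compound 2 to compound 3 (0.06 log units; within the scatter). The step from compound 1 to compound 2 is an at least 1.7-fold lower number from compound 1 to compound 2 (0.23 log units; that floor lies within the scatter).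

Compound 4 `NC(=O)c1c(NC(=O)c2ccccc2Cl)sc2c1CCN(C(=S)Nc1ccccc1Br)C2` has not been measured. It differs from compound 2 in one place: a group of 10 heavy atoms (7 carbon, 1 nitrogen, 1 sulfur, 1 bromine; one six-membered aromatic ring of carbon only) in place of a group of 9 heavy atoms (7 carbon, 2 chlorine; one six-membered aromatic ring of carbon only), on an amine nitrogen in a ring. For the measured compounds named here, none of the measured steps changes this part of the molecule in a comparable way; the two measured steps alter only the aromatic substituents and both fall within the scatter or just at its floor. Without a matching precedent, no step beyond the scatter is expected in either direction, and the estimate for compound 4 is a 1.0-fold higher number from compound 2 to compound 4 (0.02 log units; within the scatter), with the number for compound 4 expected at 30000 nM, between 8000 nM and 100000 nM.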

Compound 4, half-maximal inhibitory concentration: 24600 nM
For compound 4 the middle estimate is 1.2-fold (0.09 log units) above the measured one, and the stated range covers the measured number.
By their numbers in this assay, from the lowest: compounds 4, 2 and 3 (each within the scatter of the next). At a limit, above all of these: compound 1.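

In this assay, the amine nitrogen in the ring accepts a very different group: replacing 2,6-dichlorobenzyl with a thiourea carrying a bromine-substituted aromatic ring brings in a hydrogen-bond donor and a hydrogen-bond acceptor, yet the result is a 1.2-fold lower number from compound 2 to compound 4 (0.07 log units; within the scatter). The other new step at this position is an at least 2.0-fold lower number from compound 1 to compound 4 (0.30 log units; that floor lies within the scatter), which gives only a floor for the change. Compound 1 carries a limit of the assay, not a number: the limit of > 50000 nM in this assay, at which 1 of the 4 values shown sits.

The compounds shown leave open how much the sulfur of the thiourea contributes, which a urea with oxygen in its place could test. As far as these compounds go, it also remains open whether a carboxylic acid or a longer chain on this nitrogen would shift the number beyond the scatter.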